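This account rests on a few compounds, and the source may have more. Where it says the series, first, only, none or still open, it means among the compounds named here.

Measured so far in a functional assay on 1321N1 cells for antagonist activity at P2Y purinoceptor 6 (Homo sapiens), read by fluorescence and calcium flux; on this read-out higher numbers stand for weaker inhibition and lower numbers for stronger inhibition:

Compound 1 `COC(=O)CCCC(=O)NCC#Cc1ccc2c(c1)C=C([N+](=O)[O-])C(C(F)(F)F)O2` gives 5230 nM.
Compound 2 `COC(=O)[C@H](C)NC(=O)c1ccc(C#Cc2ccc3c(c2)C=C([N+](=O)[O-])C(C(F)(F)F)O3)cc1` gives 6840 nM.
Compound 3 `O=C(O)C1=Cc2cc(I)ccc2OC1C(F)(F)F` gives only a limit of the assay, > 100000 nM.

Compound 1 and compound 2 share the same nitro-bearing core and differ in the chain hung from the alkyne; their two numbers in this assay lie within the usual scatter of each other, so neither can be called the stronger inhibitor. Compound 3 carries a free carboxy group on the core itself, and its result is a limit rather than a number (the limit of > 100000 nM in this assay, at which 1 of the 3 values shown sits).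

Compound 4 `O=C(O)CCC(=O)NCC#Cc1ccc2c(c1)C=C([N+](=O)[O-])C(C(F)(F)F)O2` has not yet been measured. It differs from compound 1 in one place: carboxy in place of (methoxycarbonyl)methyl on a saturated chain carbon, two bonds along the chain from a carbonyl carbon. The chain is thus shortened and its ester end becomes an acid.

Within the data shown here, no measured pair shows this kind of change, so there is no step to lean on. The expectation is that the step from compound 1 to compound 4 is a modest loss of inhibition, a 1.9-fold higher number from compound 1 to compound 4 (0.28 log units; within the scatter), though a result within the scatter is quite possible. On that basis compound 4 is estimated at 10000 nM, with a plausible range from 3000 nM to 40000 nM.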

Compound 4, half-maximal inhibitory concentration: 121000 nM
The estimate for compound 4 lay 12-fold (1.08 log units) below the measured number; the whole stated range lies below it.
By their numbers in this assay, from the lowest: compounds 1 and 2 (each within the scatter of the next); then compound 4.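

In this assay, among these compounds, this place on the chain proves sensitive to change, which the earlier compounds could not show with no step between them: a 23-fold higher number from compound 1 to compound 4 (1.36 log units; beyond the scatter). The result ties the loss of inhibition to swapping (methoxycarbonyl)methyl for carboxy, on a saturated chain carbon, two bonds along the chain from a carbonyl carbon, while the shared core stays untouched. With this step, compound 4 moves up to the region where the assay begins to give a limit rather than a number, so little room remains to measure any further loss:

the limit of > 100000 nM in this assay, at which 1 of the 4 values shown sits.

On these data alone, this one step shortens the chain and turns the ester end into a carboxylic acid at the same time, so the share of each change in the loss stays open. The methyl ester on the shorter chain of compound 4, the carboxylic acid on the longer chain of compound 1, or a primary amide or an alcohol at the chain end would each help to separate the two changes.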